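Phenyl in Place of Methoxybenzyl on the Amine Nitrogen

A few compounds are considered here, and "the series" means these few. Any claim that something is new, unique, unknown or untested is made for them only; others in the source may bear on it.

Compound 1 `CCC(CO)NCc1nc2c(OCC3CCCCC3)cccc2[nH]1` gives 3500 nM in an assay on cells for inhibition of interleukin-5 receptor subunit alpha (Mus musculus), read by WST assay, with a stated time of 48 h, in the presence of a further agent that is not named here; on this read-out higher numbers stand for weaker inhibition and lower numbers for stronger inhibition.
Compound 2 `CC(C)(CO)NCc1nc2c(OCC3CCCCC3)cccc2[nH]1` gives 27500 nM in this assay.
Compound 3 `COc1ccc(CNCc2nc3c(OCC4CCCCC4)cccc3[nH]2)cc1` gives only a limit, > 30000 nM, in this assay and no number.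

Compound 3 therefore stands at the edge of what this assay can report, the point described by the limit of > 30000 nM in this assay, at which 1 of the 3 values shown sits. Compound 4 `c1ccc(NCc2nc3c(OCC4CCCCC4)cccc3[nH]2)cc1` differs from it by phenyl in place of 4-methoxybenzyl on an amine nitrogen. Among the compounds with values here, the measured steps that reach compound 3, an at least 8.5-fold higher number from compound 1 to compound 3 (0.93 log units; beyond the scatter) and an at least 1.0-fold higher number from compound 2 to compound 3 (0.03 log units; that floor lies within the scatter), both end at that limit, and neither of them changes the group that is exchanged here, so no measured step shows what this exchange does. With nothing pointing to a gain, compound 4 is expected to stay close to compound 3, an estimated change of a step that the limit leaves unreadable from compound 3 to compound 4. The estimate for compound 4 is 35000 nM, with a range from 8000 nM to 120000 nM.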

Compound 4, half-maximal inhibitory concentration: > 30000 nM
Compound 4: a limit, no number; the forecaster's own chance of this, stated with the estimate: 55%; the middle value does not contradict the limit.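

Phenyl on the amine nitrogen, like 4-methoxybenzyl, leaves the compound at the edge of what this assay can report: the limit of > 30000 nM in this assay, at which 2 of the 4 values shown sit.

The step between compound 3 and compound 4 cannot be read. Phenyl falls behind 1-(hydroxymethyl)propyl, with an at least 8.5-fold higher number from compound 1 to compound 4 (0.93 log units; beyond the scatter), whereas the comparison with 1-(hydroxymethyl)-1-methylethyl gives only an at least 1.0-fold higher number from compound 2 to compound 4 (0.03 log units; that floor lies within the scatter).

As far as these compounds go, how far compound 3 and compound 4 really differ stays open. So does whether a longer chain ending in hydroxyl, or a carboxylic acid, on this amine nitrogen would inhibit more strongly than compound 1.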